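The compounds below may be only part of what the source reports. "The series", "measured", "known", "first", "only" and "open" are said of these compounds alone.

Compound 2 `Cc1cccc(N2C(=O)N/C(=C\c3ccc(O)cc3)C2=O)c1` carries a 3-methylphenyl group on the amide-type nitrogen of the shared core. In a functional assay on NCI-H292 cells (Homo sapiens) for antiproliferative activity (a lower number here means a stronger inhibitor, a higher number a weaker inhibitor), compound 2 gives > 200000 nM, which is a limit of the assay rather than a measured number. Among the measured compounds shown here, its only measured relative is compound 1 `O=C1N/C(=C\c2ccc(O)cc2)C(=O)N1c1ccc(I)cc1`, which carries 4-iodophenyl in the same place; in this assay compound 1 gives 25500 nM. For the measured compounds named here, the step of an at least 7.8-fold higher number from compound 1 to compound 2 (0.89 log units; beyond the scatter) is the single comparison available, and it can only be bounded because the limit of > 200000 nM in this assay, at which 1 of the 2 values shown sits, is all that is known for compound 2.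

Compound 3 `O=C(Nc1ccc(Cl)cc1)c1cccc(N2C(=O)N/C(=C\c3ccc(O)cc3)C2=O)c1` differs from compound 2 by (4-chlorophenyl)carbamoyl in place of methyl on an aromatic carbon. Going by the values given here, no measured step concerns a change within the ring on the nitrogen; the one step swaps the whole aryl group, so it gives no direct guide here. With compound 2 already beyond the limit, a number may or may not appear for compound 3. On that thin basis compound 3 is expected to give about 90000 nM, within a range from 15000 nM to 400000 nM. The implied step an at least 2.2-fold lower number from compound 2 to compound 3 (0.34 log units; beyond the scatter) is thus expected to lean toward a lower number, with little confidence.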

Compound 3, half-maximal inhibitory concentration: 125000 nM
For compound 3 the middle estimate is 1.4-fold (0.14 log units) below the measured one, and the stated range covers the measured number.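

Among the compounds shown here, compound 3 shows what the earlier compounds could not: the aromatic carbon that holds the methyl group in compound 2 can carry a much larger group, (4-chlorophenyl)carbamoyl, with a further six-membered aromatic ring and a hydrogen-bond donor and acceptor, and a number still appears in this assay. The change reads as an at least 1.6-fold lower number from compound 2 to compound 3 (0.20 log units; that floor lies within the scatter), so a lower number is possible, but this step alone does not establish a real gain. The true size of the step cannot be fixed because compound 2 gives only a limit: the limit of > 200000 nM in this assay, at which 1 of the 3 values shown sits.

Still open is which part of the large group matters, since the compounds shown do not separate the carbamoyl link from the outer ring or its chlorine, so a plain phenyl ring or an unsubstituted carboxamide at this place would be informative. A small group such as an amine or a carboxylic acid on the same carbon would also show whether this position responds to anything other than size, and whether any group here can bring the number down far.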